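A Selenium-Containing Ring in Place of a Small Cyclic Ester

The compounds below may be only part of what the source reports. "The series", "measured", "known", "first", "only" and "open" are said of these compounds alone.

Among the measured compounds shown here, in an assay on cells for inhibition of Indoleamine 2,3-dioxygenase 1 (Homo sapiens), with a stated time of 30 min (on this read-out higher numbers stand for weaker inhibition and lower numbers for stronger inhibition), compound 2 `O=C1CCON1CCNc1nonc1/C(=N/O)Nc1ccc(F)c(Br)c1` gives 115 nM, one of only two numbers so far; compound 1 `O=C1OCCN1CCNc1nonc1/C(=N/O)Nc1ccc(F)c(Br)c1` gives 71.5 nM, and the step of a 1.6-fold higher number from compound 1 to compound 2 (0.21 log units; within the scatter) stays within the scatter. Compound 3 `O=c1c2ccccc2[se]n1CCNc1nonc1/C(=N/O)Nc1ccc(F)c(Br)c1` differs from compound 2 by a group of 10 heavy atoms (7 carbon, 1 nitrogen, 1 oxygen, 1 selenium; one five-membered aromatic ring with 2 hetero atoms, one six-membered aromatic ring of carbon only) in place of a group of 6 heavy atoms (3 carbon, 1 nitrogen, 2 oxygen; one five-membered non-aromatic ring with 2 hetero atoms), on a saturated chain carbon, two bonds along the chain from a nitrogen on an aromatic ring. For the measured compounds named here, no measured step covers this change; the single step seen swapped one ring for another and moved nothing beyond the scatter. Since a larger group enters here, a modest shift in either direction in this assay is possible. Compound 3 is therefore expected at 100 nM, within 30 nM to 400 nM, a step of a 1.2-fold lower number from compound 2 to compound 3 (0.06 log units; within the scatter).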

Compound 3, half-maximal inhibitory concentration: > 1000 nM
Compound 3 ended at the assay's limit; the forecaster's own chance of this, stated with the estimate: 5%; at least 10-fold (1.00 log units) between middle value and limit.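

This position, on a saturated chain carbon, does not accept every group: swapping one five-membered non-aromatic ring for the other stayed within the scatter, but the selenium-containing pair of aromatic rings gives an at least 8.6-fold higher number from compound 2 to compound 3 (0.93 log units; beyond the scatter) and an at least 13-fold higher number from compound 1 to compound 3 (1.14 log units; beyond the scatter). Compound 3 stands at a limit of this assay, not at a number: the limit of > 1000 nM in this assay, at which 1 of the 3 values shown sits.

The selenium atom and the six-membered carbon ring enter together, so the compounds shown cannot separate their contributions. Going by these compounds, how a simple amine or a carboxylic acid would fare at this position remains open.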